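The source may report more compounds than this note shows. Statements on the series, on what has been measured and on what is new or still open speak of the compounds shown alone.

Measured compounds:
compound 1 `CC(C)(C)N(NC(=O)c1ccccc1)C(=O)c1ccccc1C(F)(F)F` with 631 nM in an assay on cells for agonist activity at ecdysone receptor (Bombyx mori), read by a luciferase reporter, with a stated time of 24 h; on this read-out lower numbers stand for an effect already at smaller amounts and higher numbers for an effect only at larger amounts of compound
compound 2 `CC(C)(C)N(NC(=O)c1ccccc1Br)C(=O)c1ccccc1Cl` with 316 nM in this assay

Compound 2 gives the lower of the two numbers in this assay, but its gap to compound 1 lies within the scatter, so the two stand level. Compound 3 `CC(C)(C)N(NC(=O)c1cccc(F)c1)C(=O)c1ccccc1Cl` differs from compound 2 by 3-fluorophenyl in place of 2-bromophenyl on a carbonyl carbon. Among the measured compounds shown here, no measured pair shows this change, so its size is not known. Compound 3 is expected to give 600 nM (range 200 nM to 2000 nM) in this assay, a step of a 1.9-fold higher number from compound 2 to compound 3 (0.28 log units; within the scatter) that is estimated to be small and at most slightly toward larger amounts.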

Compound 3, half-maximal effective concentration: 69.2 nM
Beside the measured number, compound 3's estimate is 8.7-fold (0.94 log units) above it, and the stated range ends above it.
By their numbers in this assay, from the lowest: compound 3; then compounds 2 and 1 (each within the scatter of the next).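

In this assay the aryl group on this carbonyl carbon proves able to move the number beyond the scatter: 3-fluorophenyl in place of 2-bromophenyl gives a 4.6-fold lower number from compound 2 to compound 3 (0.66 log units; beyond the scatter) and so 2-bromophenyl is not needed there for a low number. This change alters both the halogen and its ring position at once, so the compounds shown cannot separate the two. Nothing measured here accounts for the step. Still open, as far as these compounds go, is how 3-bromophenyl or 2-fluorophenyl would read on this carbonyl carbon, which would separate halogen from position, and how 3-methoxyphenyl would compare.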